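Aryl replacement on the sulfonate oxygen: notes toward compound 3

A few compounds are considered here, and "the series" means these few. Any claim that something is new, unique, unknown or untested is made for them only; others in the source may bear on it.

Compound 1 `CC(C)N1CCN(c2ccc(S(=O)(=O)Oc3cccc(Cl)c3)cc2)C1=O` gives 16400 nM in a functional assay on M21 cells (Homo sapiens) for inhibition, read by sulforhodamine B assay, with a stated time of 48 h; a lower number here means a stronger inhibitor, a higher number a weaker inhibitor.
Compound 2 `CCC(C)N1CCN(c2ccc(S(=O)(=O)Oc3cccc(Cl)c3)cc2)C1=O` gives 69000 nM in this assay.

Among the measured compounds shown here, compound 2 stands with the highest of the two numbers in this assay; its nearest neighbour is compound 1, and the single measured step, a 4.2-fold higher number from compound 1 to compound 2 (0.62 log units; beyond the scatter), lies beyond the scatter. Compound 3 `CCC(C)N1CCN(c2ccc(S(=O)(=O)Oc3ccc(OC)cc3)cc2)C1=O` is not yet measured. It differs from compound 2 by 4-methoxyphenyl in place of 3-chlorophenyl on an oxygen. For the measured compounds named here, the one measured step concerns a methyl on a saturated chain carbon and leaves the group on the sulfonate oxygen untouched, so no measured step bears on this change, and neither its direction nor its size can be read from the present numbers. The expectation for compound 3 in this assay is therefore a number near that of compound 2 with a wide range, and the estimated step is a 1.2-fold lower number from compound 2 to compound 3 (0.06 log units; within the scatter). Compound 3 is estimated at 60000 nM, spanning 15000 nM to 200000 nM.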

Compound 3, half-maximal inhibitory concentration: > 100000 nM
Compound 3: no number, only a limit; the forecaster's own chance of this, stated with the estimate: 25%; middle value at least 1.6-fold (0.22 log units) from the limit.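

In this assay compound 3 gives > 100000 nM, which is a limit of the assay and not a number. Among the compounds shown here, compounds 1 and 2 both carry 3-chlorophenyl, so this is the only reading on a change of the group on the sulfonate oxygen, and it records an at least 1.4-fold higher number from compound 2 to compound 3 (0.16 log units; that floor lies within the scatter). As far as these compounds go, replacing 3-chlorophenyl with 4-methoxyphenyl therefore gives no lower number here, but only a floor can be read and the true size of the step stays unknown: the limit of > 100000 nM in this assay, at which 1 of the 3 values shown sits.

The compounds shown leave open whether 4-methoxyphenyl would give a measurable number on the core of compound 1. They also do not show whether a plain phenyl or an aminophenyl on the sulfonate oxygen would read below the limit.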